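A few compounds are considered here, and "the series" means these few. Any claim that something is new, unique, unknown or untested is made for them only; others in the source may bear on it.

Compound 1 `CCn1nc(-c2ccccn2)c2sccc2c1=O` is the reference point of this short series. In an assay on CHO cells for displacement of a labelled ligand from adenosine receptor A3 (Homo sapiens), read by scintillation counting, with a stated time of 120 min, tested at 1 uM (on this read-out lower numbers stand for less inhibition and higher numbers for more inhibition at the one concentration tested (going by the name of the read-out)), compound 1 gives 1%, level with compound 3 `Nn1nc(-c2ccccn2)c2sccc2c1=O` at the digits printed; compound 3 gives 1%. Compound 2 `CC(C)n1nc(-c2ccccn2)c2sccc2c1=O` gives 2%. The measured steps are all small: a number 1 percentage points higher from compound 1 to compound 2 (within the scatter), no change at the digits printed from compound 1 to compound 3 (within the scatter) and a number 1 percentage points lower from compound 2 to compound 3 (within the scatter), each within the scatter. Compound 4 `CCc1nn(CC)c(=O)c2ccsc12` differs from compound 1 in another place: ethyl in place of pyridin-2-yl on an aromatic carbon. Among the compounds with values here, no measured step touches the pyridin-2-yl group, so nothing in the data bears directly on this change. Within the data shown here, with every number so far low, the expectation for compound 4 is a step of a number 2 percentage points higher from compound 1 to compound 4 (within the scatter), no change beyond the scatter. Compound 4 is therefore estimated at 3%, with a range from -8% to 15%.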

Compound 4, a percentage reported as inhibition, at one concentration (the size of the read-out at that concentration, not a potency): 14%
Compound 4: the middle estimate sits 11 percentage points below what was measured, within the range that was stated.
By their numbers in this assay, from the lowest: compounds 1, 3 and 2 (each within the scatter of the next); then compound 4.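

In this assay, ethyl in place of pyridin-2-yl on this aromatic carbon gives a number 13 percentage points higher from compound 1 to compound 4 (beyond the scatter) and is the only step shown that lies beyond the scatter. Exchanges on the aromatic nitrogen among compounds 1, 2 and 3 moved the read-out by no more than the scatter, so this carbon is the one position here where a change registers. No data at hand account for the step.

Going by these compounds, whether the shift follows from the loss of the pyridine ring or from ethyl itself remains open. A phenyl ring, a longer chain or an amine on this carbon would help separate the two.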